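The compounds below may be only part of what the source reports. "The series", "measured", "known", "first", "only" and "open" are said of these compounds alone.

Three compounds have been measured in an ADME assay on microsomes from liver (Rattus norvegicus) for metabolic stability, read by LC-MS, with a stated time of 10 min, tested at 0.5 uM (a higher number here means that more of the compound is left, a lower number that less of the compound is left), so far:

compound 1 `c1ccc2c(c1)CN[C@H](CN(CCCN1CCNCC1)[C@H]1CCCc3cccnc31)C2` gives 88% of the compound remaining
compound 2 `c1ccc2c(c1)CN[C@@H](CN(CC[C@@H]1CCCNC1)[C@H]1CCCc3cccnc31)C2` gives 28% of the compound remaining
compound 3 `CN1CCN(CCCN(C[C@H]2Cc3ccccc3CN2C)[C@H]2CCCc3cccnc32)CC1` gives 2% of the compound remaining

Compound 2 stands in the middle of these three numbers, and the gaps on both sides lie beyond the scatter, with compound 3 lower and compound 1 higher.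

The account now follows the step to compound 4 `NC(=O)N1CCN(CCCN(C[C@H]2Cc3ccccc3CN2)[C@H]2CCCc3cccnc32)CC1` whose change from compound 2 is counted as (4-carbamoylpiperazin-1-yl)methyl in place of piperidin-3-yl on a saturated chain carbon, two bonds along the chain from an amine nitrogen and amounts to (4-carbamoylpiperazin-1-yl)methyl in place of piperidin-3-yl on a saturated chain carbon, two bonds along the chain from an amine nitrogen.

Going by the values given here, no pair of measured compounds differs in one place only, so the data hold no direct guide to the size of this step. All that can be read is the width of the range, with compound 3 at 2% on one end and compound 1 at 88% on the other, and this width leaves much more room above compound 2 than below it. A rise beyond the scatter is therefore expected, though with little certainty, and the estimate is a number 27 percentage points higher from compound 2 to compound 4 (beyond the scatter) as an expected change in this assay for this pair. For compound 4 the estimated value is 55% with an expected range from 25% to 85% in this measurement.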

Compound 4, percent of the compound remaining: 4%
Beside the measured number, compound 4's estimate is 51 percentage points above it; measured number below the stated range.
By their numbers in this assay, from the lowest: compounds 3 and 4 (each within the scatter of the next); then compound 2; then compound 1.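

In this assay, going by these compounds alone, the exchange of piperidin-3-yl for (4-carbamoylpiperazin-1-yl)methyl on a saturated chain carbon, two bonds along the chain from an amine nitrogen, gives the only step that can be read here (a number 24 percentage points lower from compound 2 to compound 4 (beyond the scatter)). Within the data shown here, this shows that the number responds to what stands at this position, which the earlier compounds could not show, as none of them formed a pair differing in one place. The entering group has more heavy atoms and more hydrogen-bond acceptors than the group it replaces, with the same count of donors and no net charge on either, but no measurement at hand bears on why the number falls.

With a single step, the compounds shown leave open whether the fall belongs to the piperazine ring, to the carbamoyl group or to the added methyl link. They also leave open how a simple dimethylamino group or a carboxylic acid at this place on the chain would read in this assay, and whether either would keep more of the compound left than piperidin-3-yl does.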